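Replacing an anilino group by pyrrolidinyl on a fused quinone core

The source may report more compounds than this note shows. Statements on the series, on what has been measured and on what is new or still open speak of the compounds shown alone.

Measured compounds:
compound 1, `COc1cccc(NC2=CC(=O)c3nc4n(c3C2=O)[C@H]2OC[C@@H](O)[C@H]2OC4)c1`, 7620 nM
compound 2, `O=C1C(NC2CCCC2)=CC(=O)c2c1nc1n2[C@H]2OC[C@@H](O)[C@H]2OC1`, > 16000 nM

Compound 1 carries a (3-methoxyphenyl)amino group on the shared core. In a functional assay on ECa-109 cells for inhibition, with ECa-109 cell line (Homo sapiens) as the target, read by sulforhodamine B assay (a higher number here means a weaker inhibitor, a lower number a stronger inhibitor), compound 1 gives 7620 nM, the only numerical result among the two values shown. Compound 2, which carries a cyclopentylamino group in the same place, reaches only a limit of the assay, > 16000 nM, with no number behind it; this is the limit of > 16000 nM in this assay, at which 1 of the 2 values shown sits.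

Compound 3, `O=C1C=C(N2CCCC2)C(=O)c2c1nc1n2[C@H]2OC[C@@H](O)[C@H]2OC1`, has not been measured. Its change from compound 1 is pyrrolidin-1-yl in place of (3-methoxyphenyl)amino on a double-bonded ring carbon. Among the compounds with values here, with no measured step between two compounds to lean on, the direction of the step is uncertain; the limit of compound 2 suggests that a small aliphatic ring in this place does not favour inhibition. The step from compound 1 to compound 3 is expected to be a 2.0-fold higher number from compound 1 to compound 3 (0.29 log units; within the scatter), toward weaker inhibition. Compound 3 is therefore estimated at 15000 nM, between 6000 nM and 40000 nM.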

Compound 3, half-maximal inhibitory concentration: > 16000 nM
Compound 3: only a limit was reported; the forecaster's own chance of this, stated with the estimate: 45%; middle value at least 1.0-fold (0.02 log units) from the limit.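

In this assay, compound 3 reaches only a limit, > 16000 nM, and not a number. Within the data shown here, putting pyrrolidin-1-yl in place of (3-methoxyphenyl)amino on the double-bonded ring carbon gives an at least 2.0-fold higher number from compound 1 to compound 3 (0.32 log units; beyond the scatter), the first step between two compounds that can be read here, and it shows that this change weakens inhibition beyond the scatter, though its full size stays unknown. With compound 3, the only numerical result remains that of compound 1, the one compound here that carries an aromatic ring in this group: the limit of > 16000 nM in this assay, at which 2 of the 3 values shown sit.

The compounds shown leave open how far compound 3 lies past its limit. They also leave open whether a morpholine or a benzylamino group in the same place would give a number in this assay.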